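A few compounds are considered here, and "the series" means these few. Any claim that something is new, unique, unknown or untested is made for them only; others in the source may bear on it.

Measured in a physicochemical assay for solubility, at pH 7.9; a lower number here means a less soluble compound, a higher number a more soluble compound:
- Compound 1 `O=c1c(-c2ccccc2)cn(C2CC2)c2cc(N3CCNCC3)c(F)cc12`: > 400000 nM
- Compound 2 `O=c1c(-c2ccc(F)cc2)cn(C2CC2)c2cc(N3CCNCC3)c(F)cc12`: > 400000 nM

Both readings are limits of the assay, not numbers. For compound 2 the reading is the limit > 400000 nM.

Compound 3 `O=c1c(-c2ccc(Cl)cc2)cn(C2CC2)c2cc(N3CCNCC3)c(F)cc12` carries chloro in place of fluoro on an aromatic carbon, para to a large group: chloro in place of fluoro on an aromatic carbon. Going by the values given here, the one measured step that bears on this is a step that the two limits leave unreadable from compound 1 to compound 2, so it gives no size to carry over. Among the compounds with values here, the only other guide is the limit of > 400000 nM in this assay, at which 2 of the 2 values shown sit.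

No step beyond the scatter is therefore expected in this assay. The estimated step is an at least 1.3-fold lower number from compound 2 to compound 3 (0.12 log units; that floor lies within the scatter). For compound 3 the expected solubility is 300000 nM, with an estimated range of 100000 nM to 400000 nM.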

Compound 3, solubility: > 400000 nM
Compound 3 was reported as a limit; the forecaster's own chance of this, stated with the estimate: 60%; at least 1.3-fold (0.12 log units) between middle value and limit.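

Compound 1, compound 2 and compound 3 all stand at a limit of this assay, not at a number, so no step between them can be read: the limit of > 400000 nM in this assay, at which 3 of the 3 values shown sit.

Going by these compounds, whether hydrogen, fluoro or chloro on the phenyl ring changes solubility at all remains open.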